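This account rests on a few compounds, and the source may have more. Where it says the series, first, only, none or still open, it means among the compounds named here.

In a functional assay on MDA-MB-231 cells (Homo sapiens) for cytotoxicity, read by MTT assay, with a stated time of 72 h (on this read-out higher numbers stand for weaker inhibition and lower numbers for stronger inhibition), compound 1 (`O=C1c2c[n+]([O-])c3ccccc3c2C(=O)c2c1c1ccccc1n2CCN1CCCC1`) gives 630 nM, while compound 2 (`CCCN1CCN(CCCCn2c3c(c4ccccc42)C(=O)c2c[n+]([O-])c4ccccc4c2C3=O)CC1`) gives 2980 nM, the higher of the two numbers and so the weaker inhibition. Compound 3 (`CN1CCN(CCCn2c3c(c4ccccc42)C(=O)c2c[n+]([O-])c4ccccc4c2C3=O)CC1`) departs from compound 2 by one change: 4-methylpiperazin-1-yl in place of (4-propylpiperazin-1-yl)methyl on a saturated chain carbon, three bonds along the chain from an aromatic nitrogen. It lies on a saturated chain carbon, three bonds along the chain from an aromatic nitrogen. Among the measured compounds shown here, no measured step covers this change directly. The nearest guide is the modest step of a 4.7-fold higher number from compound 1 to compound 2 (0.67 log units; beyond the scatter), which brought in 2-(4-propylpiperazin-1-yl)ethyl in place of pyrrolidin-1-yl. The new change runs partly back along that step, yet a six-membered non-aromatic ring remains, so only part of that size is expected to return. A small move towards a lower number is therefore expected, a 2.1-fold lower number from compound 2 to compound 3 (0.33 log units; beyond the scatter). The value estimated for compound 3 is 1400 nM, with an expected range from 550 nM to 3600 nM.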

Compound 3, half-maximal inhibitory concentration: 390 nM
Compound 3: middle estimate off by 3.6-fold (0.56 log units), on the high side; the whole stated range lies above it.
By their numbers in this assay, from the lowest: compounds 3 and 1 (each within the scatter of the next); then compound 2.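

In this assay, 4-methylpiperazin-1-yl in place of (4-propylpiperazin-1-yl)methyl on a saturated chain carbon, three bonds along the chain from an aromatic nitrogen, gives a 7.6-fold lower number from compound 2 to compound 3 (0.88 log units; beyond the scatter), so this position responds strongly to the change even though a six-membered non-aromatic ring with 2 hetero atoms stays in place. That ring therefore does not by itself go with the weaker inhibition of compound 2, since the comparison with pyrrolidin-1-yl gives a 1.6-fold lower number from compound 1 to compound 3 (0.21 log units; within the scatter) and leaves those two groups indistinguishable here. Nothing given here accounts for the size of the step.

The change alters the chain and the group on the piperazine together, so the compounds shown do not separate the two contributions. As far as these compounds go, whether a 4-propylpiperazin-1-yl group on the chain of compound 3, or a morpholine at the chain end, would match compound 3 also remains open.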